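Moving the chlorine on the sulfonyl side of compound 3

The source may hold more compounds than are shown below. What is called first, only, known or untested is meant among the compounds shown, and "the series" means these compounds.

Measured compounds:
compound 1 `O=C1[C@@H](NS(=O)(=O)c2cc3c(Cl)nccc3s2)CCN1CCNc1ccncc1`: 39%
compound 2 `CC(C)(C)c1ccc(S(=O)(=O)N[C@H]2CCN(Cc3cc4[nH]cccc-4n3)C2=O)cc1`: 22%
compound 3 `O=C1[C@@H](NS(=O)(=O)c2cc3c(Cl)nccc3s2)CCN1Cc1cc2c[nH]ccc-2n1`: 35%

In an assay on isolated protein for inhibition of coagulation factor X (Oryctolagus cuniculus), tested at 1 uM (a higher number here means more inhibition at the concentration tested (going by the name of the read-out), a lower number less inhibition), compound 3 gives 35%, the second highest of the three numbers. Its nearest neighbour is compound 1, which in this assay gives 39%; the step of a number 4 percentage points lower from compound 1 to compound 3 (within the scatter) is within the scatter. Compound 2, which in this assay gives 22%, lies beyond the scatter below compound 3.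

Compound 4 `O=C1[C@@H](NS(=O)(=O)c2cc3ccnc(Cl)c3s2)CCN1Cc1cc2c[nH]ccc-2n1` has the same atoms as compound 3, joined differently: a group of 10 heavy atoms (7 carbon, 1 nitrogen, 1 sulfur, 1 chlorine; one five-membered aromatic ring with 1 hetero atom, one six-membered aromatic ring with 1 hetero atom) in place of a group of 10 heavy atoms (7 carbon, 1 nitrogen, 1 sulfur, 1 chlorine; one five-membered aromatic ring with 1 hetero atom, one six-membered aromatic ring with 1 hetero atom), on a sulfonyl sulfur. Going by the values given here, no measured step touches the group on the sulfonyl sulfur; the only measured step, from compound 1 to compound 3, changes the group on the ring nitrogen instead, and compound 2 differs from compound 3 in more than one place. There is thus no direct guide, and the expected step of a number 5 percentage points lower from compound 3 to compound 4 (within the scatter) in this assay is one not beyond the scatter, with wide uncertainty. Compound 4 is estimated at 30% in this assay, within 10% to 52%.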

Compound 4, a percentage reported as inhibition, at one concentration (the size of the read-out at that concentration, not a potency): 25%
Beside the measured number, compound 4's estimate is 5 percentage points above it; measured number inside the range.
By their numbers in this assay, from the lowest: compounds 2, 4, 3 and 1 (each within the scatter of the next, the first and the last beyond it).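

In this assay, going by these compounds alone, this is the first measured step at the sulfonyl sulfur, whose other neighbour is the sulfonamide nitrogen: a number 10 percentage points lower from compound 3 to compound 4 (within the scatter). It shows that the two groups, which have the same atoms joined differently, cannot be told apart in this assay at this place, even though the step reaches the edge of what repeated measurements allow. Within the data shown here, the earlier step from compound 1 to compound 3 concerned only the group on the ring nitrogen, so this is the first reading of any change on the sulfonyl side. Nothing shown here accounts for the size of this step.

The compounds shown leave open whether a fluorine, a methyl or a nitrile in place of the chlorine would move the number beyond the scatter. They also leave open whether the same rearrangement would give a similar step with the group on the ring nitrogen of compound 1.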